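This account rests on a few compounds, and the source may have more. Where it says the series, first, only, none or still open, it means among the compounds named here.

Within the data shown here, compound 3 `CC/C(=C(/c1ccc(/C=C/C(=O)O)cc1)c1cc(F)c2[nH]ncc2c1)c1ccccc1` gives 7.5 nM in a functional assay on MCF7 cells (Homo sapiens) for cytotoxicity, read by CellTiter-Glo, with a stated time of 5 days (a higher number here means a weaker inhibitor, a lower number a stronger inhibitor), the highest of the three numbers measured so far. Compound 1 `CC/C(=C(/c1ccc(/C=C/C(=O)O)cc1)c1ccc2[nH]ncc2c1)c1ccccc1` gives 7.2 nM in this assay, and compound 2 `CC/C(=C(/c1ccc(/C=C/C(=O)O)cc1)c1ccc2[nH]ncc2c1F)c1ccccc1` gives 3 nM. Placing a fluoro where compound 3 carries it gave a 1.0-fold higher number from compound 1 to compound 3 (0.02 log units; within the scatter), while the fluoro of compound 2 gave a 2.4-fold lower number from compound 1 to compound 2 (0.38 log units; beyond the scatter), and moving between those two fluoro positions gave a 2.5-fold higher number from compound 2 to compound 3 (0.40 log units; beyond the scatter). Compound 4 `CC/C(=C(/c1ccc(/C=C/C(=O)O)cc1)c1cc(Cl)c2[nH]ncc2c1)c1ccccc1` differs from compound 3 by chloro in place of fluoro on an aromatic carbon. Among the measured compounds shown here, no measured step swaps one halogen for another, and the one change at this spot stayed within the scatter, so compound 4 is expected to show a 1.1-fold lower number from compound 3 to compound 4 (0.03 log units; within the scatter). The estimate for compound 4 is 7 nM, between 3 nM and 17 nM.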

Compound 4, half-maximal inhibitory concentration: 56 nM
Compound 4: middle estimate off by 8.0-fold (0.90 log units), on the low side; measured number above the stated range.
By their numbers in this assay, from the lowest: compound 2; then compounds 1 and 3 (each within the scatter of the next); then compound 4.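

Here the identity of the halogen counts: in this assay, fluoro at this spot left the number within the scatter of hydrogen, whereas chloro weakens the compound (a 7.5-fold higher number from compound 3 to compound 4 (0.87 log units; beyond the scatter)) and (a 7.8-fold higher number from compound 1 to compound 4 (0.89 log units; beyond the scatter)). Against the other fluoro position the gap is wider still (a 19-fold higher number from compound 2 to compound 4 (1.27 log units; beyond the scatter)), so this spot is sensitive to which single atom it carries. No measurement here explains why chloro differs from fluoro. Open, on these data alone, is whether methyl, methoxy or an amine at this spot would track fluoro or chloro, and whether chloro placed where compound 2 carries its fluoro would weaken the compound too.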